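This account rests on a few compounds, and the source may have more. Where it says the series, first, only, none or still open, it means among the compounds named here.

Measured so far in a functional assay on the whole organism with Rattus norvegicus as the target, at a dose of 25 mg/kg by the intravenous route (on this read-out lower numbers stand for an effect already at smaller amounts and higher numbers for an effect only at larger amounts of compound), as the read-out
- compound 1 `O=C(O)c1ccc(NC(=O)c2ccc(C(=O)O)cc2)cc1` gives 25.4 mg/kg
- compound 2 `CCCCc1ccc(C(=O)Nc2cc(C(=O)O)cc(C(=O)O)c2)cc1` gives 12.3 mg/kg
- compound 3 `O=C(Nc1ccccc1)c1ccc(-c2nn[nH]n2)cc1` gives 8.4 mg/kg

Compound 2, at 12.3 mg/kg in this assay, lies within the scatter of compound 3. Its number is lower than that of compound 1, and that gap falls just beyond the scatter.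

The next compound to be tested is compound 4 `O=C(O)c1cc(NC(=O)c2ccc([N+](=O)[O-])cc2)cc(C(=O)O)c1`, which has nitro in place of butyl on an aromatic carbon, para to a large group. Counted out, the change is nitro in place of butyl on an aromatic carbon and the rest of the structure stays as in compound 2.

Among the measured compounds shown here, no two measured compounds differ in one place only, so no measured step speaks directly to this change. For the measured compounds named here, the only guide is the narrow spread of the three numbers, whose upper end is compound 1 at 25.4 mg/kg in these notes. A step within the scatter is therefore expected, with a slight lean towards a higher number. The estimate amounts to a 1.2-fold higher number from compound 2 to compound 4 (0.09 log units; within the scatter) as the expected step, and a wide range is kept around it. For compound 4 the expected value is 15 mg/kg with an estimated range from 6 mg/kg to 35 mg/kg in this read-out.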

Compound 4, dose for 50% inhibition: 9.8 mg/kg
Beside the measured number, compound 4's estimate is 1.5-fold (0.18 log units) above it, and the stated range covers the measured number.
By their numbers in this assay, from the lowest: compounds 3, 4 and 2 (each within the scatter of the next); then compound 1.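

Among the compounds shown here, this is the first pair that differs in one place only. In this assay, nitro in place of butyl on an aromatic carbon, para to a large group, gives a 1.3-fold lower number from compound 2 to compound 4 (0.10 log units; within the scatter) and so adds a direct reading at this position. The exchange replaces a carbon-only chain with a group of nitrogen and oxygen that carries hydrogen-bond acceptors, yet the read-out does not separate the two compounds, so at this position and on this core the change leaves the dose within the scatter. No measurement of any property of these compounds is available to account for this result.

This single step does not show whether the position is tolerant in general or whether butyl and nitro merely happen to read alike, and an amine, a carboxylic acid or a longer chain on the same aromatic carbon would help to settle that. Going by these compounds, whether the same exchange would also stay within the scatter on another core remains open.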